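This account rests on a few compounds, and the source may have more. Where it says the series, first, only, none or still open, it means among the compounds named here.

Working notes on the series. In a functional assay on HL-60 cells (Homo sapiens) for antiproliferative activity, read by XTT assay, with a stated time of 72 h (a lower number here means a stronger inhibitor, a higher number a weaker inhibitor), compound 1 `C#Cc1cn([C@@H]2O[C@H](CO)[C@@H](O)[C@H]2O)c2ncnc(OC)c12` gives 190 nM. Compound 2 `Nc1nc(N)c2c(-c3ccccc3)cn([C@@H]3O[C@H](CO)[C@@H](O)[C@H]3O)c2n1` reaches only the assay limit in this assay, > 15000 nM. Compound 3 `Cc1nc(N)c2c(-c3ccccc3)cn([C@@H]3O[C@H](CO)[C@@H](O)[C@H]3O)c2n1` likewise stands at a limit in this assay, > 20000 nM, so its position is bounded from one side only. Among the measured compounds shown here, the single measured step, a step that the two limits leave unreadable from compound 2 to compound 3, has no readable size. Compound 4 `Cc1nc(N)c2c(-c3ccco3)cn([C@@H]3O[C@H](CO)[C@@H](O)[C@H]3O)c2n1` differs from compound 3 by furan-2-yl in place of phenyl on an aromatic carbon. For the measured compounds named here, no measured step involves this change, and the one step in hand gives no size, so no direction beyond the scatter can be read for it. Compound 4 is expected to stay close to where compound 3 stands, the expected step being a number no higher from compound 3 to compound 4 (the limit leaves the size open). Compound 4 is therefore estimated at 20000 nM, with a range from 5000 nM to 60000 nM.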

Compound 4, half-maximal inhibitory concentration: > 20000 nM
Compound 4: only a limit was reported (the forecaster's own chance of this, stated with the estimate: 70%); the middle value sits exactly at the limit.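

Compound 3 and compound 4 both stand at a limit in this assay, so the step between them cannot be read: the limit of > 20000 nM in this assay, at which 2 of the 4 values shown sit.

The compounds shown leave open whether furan-2-yl and phenyl differ at all on the shared core.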